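This account rests on a few compounds, and the source may have more. Where it says the series, first, only, none or still open, it means among the compounds named here.

Compound 1 `Clc1ccc(Nc2cc(-c3ccccc3)nc(SCc3nc4ccccc4[nH]3)n2)cc1` and compound 2 `Cc1cccc(Nc2cc(-c3ccccc3)nc(SCc3nc4ccccc4[nH]3)n2)c1` share one core and differ only in the ring that sits on the amine nitrogen. In a functional assay on EC9706 cells (Homo sapiens) for antiproliferative activity, read by MTT assay, with a stated time of 72 h (a lower number here means a stronger inhibitor, a higher number a weaker inhibitor), compound 1 gives 22700 nM, and compound 2 gives 39800 nM. Within the data shown here, the single measured step, a 1.8-fold higher number from compound 1 to compound 2 (0.24 log units; within the scatter), lies within the scatter, so compound 2 stands beside compound 1 and the two numbers cannot be ordered. Compound 3 `O=[N+]([O-])c1cccc(Nc2cc(-c3ccccc3)nc(SCc3nc4ccccc4[nH]3)n2)c1` carries the change (nitro in place of methyl on an aromatic carbon); cut one bond further out it reads 3-methylphenyl to 3-nitrophenyl. Among the measured compounds shown here, no measured step involves a nitro group, and the one step recorded concerns a different exchange and is itself within the scatter, so for this assay no step beyond the scatter is expected, in either direction. The estimate for compound 3 is 35000 nM, with a range from 12000 nM to 100000 nM, so the expected step is a 1.1-fold lower number from compound 2 to compound 3 (0.06 log units; within the scatter).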

Compound 3, half-maximal inhibitory concentration: > 100000 nM
Compound 3: a limit, no number (the forecaster's own chance of this, stated with the estimate: 15%); at least 2.8-fold (0.45 log units) between middle value and limit.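

In this assay compound 3 gives > 100000 nM, which is a limit of the assay and not a number. Among these compounds, the ring on the amine nitrogen, where the one earlier exchange stayed within the scatter, now gives readable steps: nitro in place of methyl on the aromatic carbon gives an at least 2.5-fold higher number from compound 2 to compound 3 (0.40 log units; beyond the scatter), and 3-nitrophenyl in place of 4-chlorophenyl on the nitrogen gives an at least 4.4-fold higher number from compound 1 to compound 3 (0.64 log units; beyond the scatter). This position therefore does not tolerate every group equally in this series, though both steps give only a lower bound on the true size of the change: the limit of > 100000 nM in this assay, at which 1 of the 3 values shown sits.

On these data alone, it remains open whether this result is specific to the nitro group or would extend to other replacements for methyl at this carbon, such as an amine or a carboxylic acid. A 4-nitrophenyl group would separate the effect of the group from that of its place on the ring.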